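This account rests on a few compounds, and the source may have more. Where it says the series, first, only, none or still open, it means among the compounds named here.

Compound 1 `CC(C)(C)NCc1c(C(=O)O)nn(-c2ccc(Cl)cc2)c1-c1ccc(Cl)cc1`: > 599000 nM
Compound 2 `COc1ccc(-c2c(CNC(C)(C)C)c(C(=O)O)nn2-c2ccc(Cl)cc2)cc1`: > 605000 nM

In a functional assay on 786-0 cells (Homo sapiens) for inhibition, read by sulforhodamine B assay, with a stated time of 48 h (on this read-out higher numbers stand for weaker inhibition of growth and lower numbers for stronger inhibition of growth), compound 2 stands only at a limit, > 605000 nM. Compound 1 also stands only at a limit, > 599000 nM. Compound 3 `CC(C)(C)NCc1c(C(=O)O)nn(-c2ccc(Cl)cc2)c1-c1ccc([N+](=O)[O-])cc1` has nitro in place of methoxy on an aromatic carbon, para to a large group: nitro in place of methoxy on an aromatic carbon. Within the data shown here, the one measured step bearing on this change is a step that the two limits leave unreadable from compound 1 to compound 2, so it offers no size to carry over. No step beyond the scatter is therefore expected, and no direction can be given. The expected step is an at least 1.0-fold lower number from compound 2 to compound 3 (0.01 log units; that floor lies within the scatter). The estimated value for compound 3 is 580000 nM, with an expected range of 150000 nM to 700000 nM.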

Compound 3, concentration for 50% growth inhibition: 104000 nM
Compound 3: the middle estimate sits 5.6-fold (0.75 log units) above what was measured; measured number below the stated range.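

In this assay, among these compounds, nitro on an aromatic carbon, para to a large group, gives the first readable number at this place: an at least 5.8-fold lower number from compound 2 to compound 3 (0.76 log units; beyond the scatter), and, with chloro as the group replaced, an at least 5.7-fold lower number from compound 1 to compound 3 (0.76 log units; beyond the scatter). Both steps are floors because compound 1 stands only at a limit: the limit of > 599000 nM in this assay, at which 1 of the 3 values shown sits. Compound 2 likewise stands only at a limit: the limit of > 605000 nM in this assay, at which 1 of the 3 values shown sits.

From the compounds shown here alone, the true size of either step stays open. So does whether an amine or a carboxylic acid at this place would also give a readable number.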